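The source may hold more compounds than are shown below. What is called first, only, known or untested is meant among the compounds shown, and "the series" means these compounds.

Compound 3 `Oc1ccc(-c2cc(-c3ccccc3C(F)(F)F)cc(-c3cccc(O)c3)n2)cc1` is the reference point here. In a functional assay on T47D cells (Homo sapiens) for inhibition (on this read-out higher numbers stand for weaker inhibition and lower numbers for stronger inhibition), compound 3 gives 3210 nM. Two close relatives have been measured alongside it. Compound 1 `Oc1ccc(-c2cc(-c3ccc(F)cc3)cc(-c3cccc(O)c3)n2)cc1` gives 5000 nM in this assay, and compound 2 `Oc1cccc(-c2cc(-c3ccccc3C(F)(F)F)cc(-c3cccc(O)c3)n2)c1` gives 4350 nM. Compound 3 therefore sits at the low end of the three numbers, but only nominally: the step of a 1.6-fold lower number from compound 1 to compound 3 (0.19 log units; within the scatter) and the step of a 1.4-fold lower number from compound 2 to compound 3 (0.13 log units; within the scatter) both fall within the scatter, so the three compounds cannot be told apart on this read-out.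

Compound 4 `Oc1ccc(-c2cc(-c3ccccc3OC(F)(F)F)cc(-c3cccc(O)c3)n2)cc1` differs from compound 3 in one place: trifluoromethoxy in place of trifluoromethyl on an aromatic carbon. The step that comes closest to this change is a 1.6-fold lower number from compound 1 to compound 3 (0.19 log units; within the scatter), which brought the trifluoromethyl group onto the aryl ring in the first place and moved the number only within the scatter. The other step, a 1.4-fold lower number from compound 2 to compound 3 (0.13 log units; within the scatter), concerns the hydroxyphenyl groups and does not touch the site of the present change. Neither step gives grounds for expecting a movement beyond the scatter in this assay in either direction. Compound 4 is therefore estimated at 3500 nM, with a likely range from 1500 nM to 8000 nM, meaning an expected step of a 1.1-fold higher number from compound 3 to compound 4 (0.04 log units; within the scatter).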

Compound 4, half-maximal inhibitory concentration: 7300 nM
Compound 4: the middle estimate sits 2.1-fold (0.32 log units) below what was measured; the measured number falls inside the stated range.
By their numbers in this assay, from the lowest: compounds 3, 2, 1 and 4 (each within the scatter of the next, the first and the last beyond it).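

Placing trifluoromethoxy instead of trifluoromethyl on this aromatic carbon, ortho to a large group, gives a 2.3-fold higher number from compound 3 to compound 4 (0.36 log units; beyond the scatter) in this assay. This modest step is the only one in the set that lies beyond the scatter, whereas a 1.6-fold lower number from compound 1 to compound 3 (0.19 log units; within the scatter) and a 1.4-fold lower number from compound 2 to compound 3 (0.13 log units; within the scatter) did not, so this position does distinguish between these two fluorinated groups, with the trifluoromethoxy compound showing the weaker inhibition. No supporting measurement is available to explain the difference, and this single pair cannot assign it to any feature of either group.

The compounds shown leave open whether a methoxy group, a methyl group or a chlorine atom at this place would keep the number close to that of compound 3 or shift it in the direction seen for compound 4. They also leave open whether the same exchange would produce a similar step with 3-hydroxyphenyl in place of 4-hydroxyphenyl, the arrangement found in compound 2.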